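This account rests on a few compounds, and the source may have more. Where it says the series, first, only, none or still open, it means among the compounds named here.

In an ADME assay on microsomes from liver (Homo sapiens) for metabolic stability (on this read-out higher numbers stand for a longer-lived compound and lower numbers for a shorter-lived compound), compound 1 (`CC(C)[C@@H](c1ccc(-c2ccc3cccc(F)c3c2)[nH]c1=O)[C@@H]1OC(=O)NC1=O`) gives > 3 h, which is a limit of the assay. Compound 3 (`CC(C)[C@@H](c1ccc(-c2ccc3cccc(F)c3c2)[nH]c1=O)[C@H]1OC(=O)NC1=O`) gives > 3 h, also a limit, so no number is known for it. Compound 2 (`CC(C)[C@H](C[C@H]1OC(=O)NC1=O)c1ccc(-c2ccc3cccc(F)c3c2)[nH]c1=O`) gives 1.68 h, a true number. Compound 4 (`CC(C)[C@H](C[C@H]1SC(=O)NC1=O)c1ccc(-c2ccc3cccc(F)c3c2)[nH]c1=O`) differs from compound 3 as follows: (2,4-dioxo-1,3-thiazolidin-5-yl)methyl in place of 2,4-dioxo-1,3-oxazolidin-5-yl on a saturated chain carbon bound to an aromatic carbon and a saturated chain carbon. Here (2,4-dioxo-1,3-thiazolidin-5-yl)methyl stands in place of 2,4-dioxo-1,3-oxazolidin-5-yl. Two measured steps add or remove the same methyl link: an at least 1.7-fold lower number from compound 1 to compound 2 (0.25 log units; that floor lies within the scatter), and an at least 1.7-fold higher number from compound 2 to compound 3 (0.25 log units; that floor lies within the scatter). Among the measured compounds shown here, no measured compound carries the sulfur-containing ring. A modest fall is therefore expected, resting on compound 2 at 1.68 h, and the expected step is an at least 2.0-fold lower number from compound 3 to compound 4 (0.30 log units; that floor lies within the scatter). Compound 4 is estimated at 1.5 h, within an expected range of 0.7 h to 3 h.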

Compound 4, half-life: 0.67 h
Beside the measured number, compound 4's estimate is 2.2-fold (0.35 log units) above it, outside the stated range (below it).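

In this assay, among the compounds shown here, 2,4-dioxo-1,3-thiazolidin-5-yl in place of 2,4-dioxo-1,3-oxazolidin-5-yl gives the first step at this place that is fully read and lies beyond the scatter: a 2.5-fold lower number from compound 2 to compound 4 (0.40 log units; beyond the scatter). With the methyl link added as well, the change gives an at least 4.4-fold lower number from compound 3 to compound 4 (0.65 log units; beyond the scatter) and an at least 4.4-fold lower number from compound 1 to compound 4 (0.65 log units; beyond the scatter). Compound 1 and compound 3 each stand at a limit, so these two sizes are floors only: the limit of > 3 h in this assay, at which 2 of the 4 values shown sit.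

On these data alone, what 2,4-dioxo-1,3-thiazolidin-5-yl does without the methyl link stays open. So does the effect of a carboxylic acid or a longer chain at this place.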